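The source may report more compounds than this note shows. Statements on the series, on what has been measured and on what is new or still open speak of the compounds shown alone.

In an ADME assay on the whole organism (strain Balb/c) for metabolic stability, with Mus musculus as the target, read by LC-MS, at a dose of 3 mg/kg by the intravenous route (on this read-out higher numbers stand for a longer-lived compound and lower numbers for a shorter-lived compound), compound 1 `CC(Oc1ccc(F)c(C(N)=O)c1F)c1nc(-c2ccc(C(F)(F)F)cc2)c(Br)o1` gives 1.05 h and compound 2 `CC(Oc1ccc(F)c(C(N)=O)c1F)c1nc(-c2ccc(OC(F)(F)F)cc2)c(Br)o1` gives 0.883 h. Within the data shown here, these are the only two numbers so far, and compound 2 stands within the scatter of compound 1. Among the measured compounds shown here, the single measured step, a 1.2-fold lower number from compound 1 to compound 2 (0.08 log units; within the scatter), is trifluoromethoxy in place of trifluoromethyl on an aromatic carbon.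

Compound 3 `CC(Oc1ccc(F)c(C(N)=O)c1F)c1nc(-c2ccc(OC(F)(F)F)cc2)c(Cl)o1` departs from compound 2 in one place: chloro in place of bromo on an aromatic carbon. This is chloro in place of bromo on an aromatic carbon, next to the ring oxygen of the five-membered aromatic ring. For the measured compounds named here, no measured step covers a change at this place, so the data offer no direct guide. The nearest evidence is indirect: a one-group exchange elsewhere on the shared core, a 1.2-fold lower number from compound 1 to compound 2 (0.08 log units; within the scatter), stayed within the scatter. On that thin basis, no shift beyond the scatter is expected in this assay, and the estimate stays anchored on compound 2 at 0.883 h. The expected step is a 1.0-fold higher number from compound 2 to compound 3 (0.01 log units; within the scatter). Compound 3 is estimated at 0.9 h, with an expected range of 0.45 h to 1.7 h.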

Compound 3, half-life: 1.32 h
Compound 3: the middle estimate sits 1.5-fold (0.17 log units) below what was measured; low and high end bracket the measured number.
By their numbers in this assay, from the lowest: compounds 2, 1 and 3 (each within the scatter of the next).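

In this assay, among these compounds, the exchange of chloro for bromo, on an aromatic carbon next to the ring oxygen of the five-membered aromatic ring, gives a 1.5-fold higher number from compound 2 to compound 3 (0.17 log units; within the scatter) and is the first reading at this position. This carbon therefore tolerates one halogen in place of the other without a step beyond the scatter, and the half-life stays in the same narrow band as before. The exchange at the other end of the molecule, a 1.2-fold lower number from compound 1 to compound 2 (0.08 log units; within the scatter), also stays within the scatter, so both one-place changes read so far leave this read-out essentially unmoved, and nothing available bears on what sets the half-life of these compounds.

Among the compounds shown here, both groups tested at this carbon are halogens, so it remains open whether a hydrogen, a methyl or a nitrile there would also stay within the scatter or would produce the first clear step. Also open, going by these compounds, is whether the amide on the shared core matters more for half-life than either position changed so far, for example with a carboxylic acid or a nitrile in its place.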